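The source may hold more compounds than are shown below. What is called first, only, known or untested is meant among the compounds shown, and "the series" means these compounds.

Working notes on the series, all read in a functional assay on PC-3 cells (Homo sapiens) for cytotoxicity, read by MTT assay, with a stated time of 48 h; a lower number here means a stronger inhibitor, a higher number a weaker inhibitor. Compound 1 `COc1cc(-c2noc(N)c2-c2ccc(Cl)cc2)cc(OC)c1OC` gives > 50000 nM, which is a limit of the assay. Compound 2 `COc1ccc(-c2c(-c3cc(OC)c(OC)c(OC)c3)noc2NC(C)=O)cc1` gives > 50000 nM, also a limit. Compound 3 `COc1ccc(-c2c(-c3cc(OC)c(OC)c(OC)c3)noc2NC(C)=O)cc1OC` gives > 50000 nM, again a limit, so it has no number of its own and stands with the other two: the limit of > 50000 nM in this assay, at which 3 of the 3 values shown sit.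

Compound 4 `COc1cc(-c2noc(NC(C)=O)c2-c2ccc(Cl)cc2)cc(OC)c1OC` is the next to be read. It differs from compound 3 by 4-chlorophenyl in place of 3,4-dimethoxyphenyl on an aromatic carbon. The change is 4-chlorophenyl in place of 3,4-dimethoxyphenyl on an aromatic carbon, next to the ring atom that bears an acetamido group.

Within the data shown here, the only measured step, a step that the two limits leave unreadable from compound 2 to compound 3, offers no size to carry over to this change. The nearest evidence is indirect. Compound 1 already carries the 4-chlorophenyl group, and its > 50000 nM is a limit as well. Nothing among the three compounds gives a measured potency for this change to raise or lower.

No step beyond the scatter is therefore expected in this assay, in either direction, and the estimated a number no higher from compound 3 to compound 4 (the limit leaves the size open) should be read with that in mind. For compound 4 the expected value is 50000 nM, with an estimated range of 20000 nM to 100000 nM, and a report as a limit is the likeliest outcome.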

Compound 4, half-maximal inhibitory concentration: 1910 nM
Compound 4: middle estimate off by 26-fold (1.42 log units), on the high side, and the stated range ends above it.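

In this assay, the aromatic carbon next to the ring atom that bears an acetamido group proves sensitive to what it carries: with 4-chlorophenyl in place of 3,4-dimethoxyphenyl there is an at least 26-fold lower number from compound 3 to compound 4 (1.41 log units; beyond the scatter), and with chloro in place of methoxy there is an at least 26-fold lower number from compound 2 to compound 4 (1.41 log units; beyond the scatter). The 4-chlorophenyl group is not enough on its own, since compound 1 carries it too and acetyl in place of hydrogen on the nitrogen gives an at least 26-fold lower number from compound 1 to compound 4 (1.41 log units; beyond the scatter). Among the compounds shown, only compound 4, which combines the acetamido and 4-chlorophenyl groups, gives a readable value, and the other three stay at a limit of the assay: the limit of > 50000 nM in this assay, at which 3 of the 4 values shown sit.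

On these data alone, the step between compound 2 and compound 3 cannot be read, and the three new steps give only a lower bound on their size, so the full effect of each change remains open. Also open, as far as these compounds go, is whether fluoro, bromo or methyl in place of the chloro, or a propionyl group or other longer acyl chain in place of the acetyl, would keep this level of activity.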